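Replacing the group on the carbonyl carbon of compound 2

This account rests on a few compounds, and the source may have more. Where it says the series, first, only, none or still open, it means among the compounds named here.

Going by the values given here, in an ADME assay on L6 cells (Rattus norvegicus) for cytotoxicity, read by resazurin assay, with a stated time of 70 h (a higher number here means a weaker inhibitor, a lower number a stronger inhibitor), compound 2 `COc1cc(NC(C)CCCNC(=O)/C=C/c2ccccc2F)c2ncccc2c1` gives 1.5 ug/mL, the only exact number so far. Compound 1 `COc1ccc(/C=C/C(=O)NCCCC(C)Nc2cc(OC)cc3cccnc23)cc1` gives > 100 ug/mL, which is a limit and not a number. Among the compounds with values here, the one measured step, an at least 66-fold lower number from compound 1 to compound 2 (1.82 log units; beyond the scatter), is large and beyond the scatter, so a swap on this chain can move the number far. Compound 3 `COc1cc(NC(C)CCCNC(=O)Nc2ccc(O)cc2)c2ncccc2c1` has (4-hydroxyphenyl)amino in place of 2-(2-fluorophenyl)ethenyl on a carbonyl carbon. This is a different swap, so that step is only a loose guide. The expected change, towards a weaker inhibitor, is an 8.0-fold higher number from compound 2 to compound 3 (0.90 log units; beyond the scatter). For compound 3 the estimated value is 12 ug/mL, with a range from 2.5 ug/mL to 70 ug/mL.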

Compound 3, half-maximal inhibitory concentration: 14.8 ug/mL
Estimate against measurement, compound 3: 1.2-fold (0.09 log units) below, within the range that was stated.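

In this assay, the carbonyl carbon proves to be a place where a swap moves the number beyond the scatter, though modestly: a 9.9-fold higher number from compound 2 to compound 3 (0.99 log units; beyond the scatter). The entering (4-hydroxyphenyl)amino does not bring the number back to where 2-(4-methoxyphenyl)ethenyl left it: an at least 6.7-fold lower number from compound 1 to compound 3 (0.82 log units; beyond the scatter). That second step is read against a limit, not a number: the limit of > 100 ug/mL in this assay, at which 1 of the 3 values shown sits.

The compounds shown leave open which part of the new group carries the step, the amino link or the hydroxyl on the ring. A plain phenylamino group on that carbonyl carbon would separate the two.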